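Amide substituent variation and expected paw edema inhibition

The source may report more compounds than this note shows. Statements on the series, on what has been measured and on what is new or still open speak of the compounds shown alone.

Measured so far in a functional assay on the whole organism (strain Wistar) for inhibition, with Rattus norvegicus as the target, read by paw edema, with stated times of 60 min and 24 h, at a dose of 100 mg/kg by the oral route; on this read-out lower numbers stand for less inhibition and higher numbers for more inhibition at the one dose given (going by the name of the read-out):
compound 1 `COc1cc2c(cc1OC)C(CC(=O)N(C)C)CC2` gives 23.3%
compound 2 `CCCCNC(=O)CC1CCc2cc(OC)c(OC)cc21` gives 36.7%
compound 3 `CCCCCNC(=O)CC1CCc2cc(OC)c(OC)cc21` gives 46.7%

Compound 3 stands highest of the three numbers in this assay. Its nearest neighbour is compound 2, and that gap, a number 10 percentage points higher from compound 2 to compound 3 (within the scatter), lies within the scatter, so the two cannot be ordered; only the gap to compound 1, a number 23.4 percentage points higher from compound 1 to compound 3 (beyond the scatter), is beyond the scatter.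

Compound 4 `COc1cc2c(cc1OC)C(CC(=O)NCCO)CC2` differs from compound 3 by hydroxy in place of propyl on a saturated chain carbon, two bonds along the chain from an amide-type nitrogen. The measured steps all concern the amide substituent: a number 13.4 percentage points higher from compound 1 to compound 2 (beyond the scatter) and a number 23.4 percentage points higher from compound 1 to compound 3 (beyond the scatter) show that exchanging dimethylamino for butylamino or pentylamino raises inhibition beyond the scatter, while a number 10 percentage points higher from compound 2 to compound 3 (within the scatter), one more chain carbon, stays within the scatter. None of these steps brings in a hydroxy group, so they bear only on the loss of the propyl part. (2-Hydroxyethyl)amino is shorter than butylamino, and the shorter dimethylamino of compound 1 gave the lowest number, so a downward step is expected in this assay, roughly a number 16.7 percentage points lower from compound 3 to compound 4 (beyond the scatter). Compound 4 is estimated at 30%, with a range from 15% to 45%.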

Compound 4, a percentage reported as inhibition, in the whole organism at one dose (the size of the read-out at that dose, not a potency): 13.3%
The estimate for compound 4 lay 16.7 percentage points above the measured number; measured number below the stated range.
By their numbers in this assay, from the lowest: compounds 4 and 1 (each within the scatter of the next); then compounds 2 and 3 (each within the scatter of the next).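

Replacing the propyl part with hydroxy in this assay gives a number 33.4 percentage points lower from compound 3 to compound 4 (beyond the scatter) and, with ethyl as the group replaced, a number 23.4 percentage points lower from compound 2 to compound 4 (beyond the scatter) on the same chain carbon, so (2-hydroxyethyl)amino does not retain the higher numbers seen with pentylamino and butylamino. Against the dimethylamino amide, the change gives a number 10 percentage points lower from compound 1 to compound 4 (within the scatter) and leaves compound 4 and compound 1 unordered, so the amide hydrogen shared by compound 2, compound 3 and compound 4 does not by itself go with the higher numbers. No measurement here accounts for the loss of inhibition at this position.

The step from pentylamino to (2-hydroxyethyl)amino shortens the chain and adds hydroxy at once, so the compounds shown do not separate these two changes; ethylamino and 2-methoxyethylamino would be the closest comparisons. As far as these compounds go, it also remains open whether the numbers keep rising with a longer chain such as hexylamino, or whether hydroxy placed at the end of a pentyl chain, as in 5-hydroxypentylamino, keeps the inhibition of the pentylamino amide.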